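The compounds below may be only part of what the source reports. "The series", "measured", "known", "first", "only" and "open" are said of these compounds alone.

In a functional assay on the whole organism (artery, strain albino) with Rattus norvegicus as the target, with a stated time of 240 min, at a dose of 10 mg/kg by the oral route (a lower number here means less inhibition, a higher number more inhibition at the dose given (going by the name of the read-out)), compound 1 `COc1ccc(C2N=C(SCc3cccc(Cl)c3)NC(C)=C2C(=O)Nc2ccc(Br)cc2)cc1` gives 33.8%. Among the compounds with values here, compound 2 `COc1ccc(C2N=C(SCc3ccc(Cl)cc3)NC(C)=C2C(=O)Nc2ccc(Br)cc2)cc1` gives 29.2% in this assay, so the two numbers lie within the scatter of each other, the single measured step being a number 4.6 percentage points lower from compound 1 to compound 2 (within the scatter). Compound 3 `COc1ccc(C2N=C(SCc3ccc(F)cc3)NC(C)=C2C(=O)Nc2ccc(Br)cc2)cc1` differs from compound 2 in one place: fluoro in place of chloro on an aromatic carbon. Within the data shown here, no measured step in this assay replaces one halogen by another on this ring; the one step in hand, which moved the chloro group from one ring carbon to another, stayed within the scatter. Among the measured compounds shown here, the only guidance from compound 1 and compound 2 is thus that a small change on this ring left this assay essentially unmoved. The expected step is therefore a number 0.2 percentage points lower from compound 2 to compound 3 (within the scatter), nothing beyond the scatter. The estimate for compound 3 in this assay is 29%, with a range from 15% to 43%. For the measured compounds named here, only two compounds have been measured, and the range is set wide to reflect that.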

Compound 3, a percentage reported as inhibition, in the whole organism at one dose (the size of the read-out at that dose, not a potency): 22.1%
For compound 3 the middle estimate is 6.9 percentage points above the measured one, within the range that was stated.
By their numbers in this assay, from the lowest: compounds 3, 2 and 1 (each within the scatter of the next, the first and the last beyond it).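

In this assay, within the data shown here, the first halogen exchange at this position gives a number 7.1 percentage points lower from compound 2 to compound 3 (within the scatter), so replacing chloro with fluoro on this aromatic carbon does not separate the two compounds. Among these compounds, the 4-fluorophenyl group in place of the 3-chlorophenyl group does produce the first step beyond the scatter, a number 11.7 percentage points lower from compound 1 to compound 3 (beyond the scatter), although this step is modest and compound 2 remains within the scatter of both compound 1 and compound 3. This series therefore shows a measurable difference only between its two end compounds, and no measurement is available to explain that difference.

From the compounds shown here alone, it remains open whether a group other than a halogen on this ring, such as a nitrile or an amine, would move the inhibition beyond the scatter of all three compounds. Also open, going by these compounds, is whether a longer chain in place of the benzyl carbon would do so, and since each result comes from a single dose, these numbers give no measure of potency.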